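Oxime to aminophenyl imine on a bis-benzyloxy coumarin core

The source may report more compounds than this note shows. Statements on the series, on what has been measured and on what is new or still open speak of the compounds shown alone.

Measured compounds:
compound 1 `O=c1cc(/C=N\c2ccccc2O)c2c(OCc3ccccc3)cc(OCc3ccccc3)cc2o1`, 348000 nM
compound 2 `O=c1cc(/C=N\c2ccc(O)cc2)c2ccc(OCc3ccccc3)cc2o1`, 233000 nM
compound 3 `O=c1cc(/C=N\O)c2c(OCc3ccccc3)cc(OCc3ccccc3)cc2o1`, "not active" (no number reported)

All three share a coumarin core carrying an imine; compound 1 and compound 2 carry an aryl group on the imine nitrogen and both give numbers of similar size in a functional assay, read by spectrophotometry, with a stated time of 1 h; a higher number here means a weaker inhibitor, a lower number a stronger inhibitor. Compound 3 carries a hydroxy group on that nitrogen instead, and in this assay compound 3 is reported as not active, with no number attached. It therefore stands below both aryl imines, but by an amount that cannot be stated.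

Compound 4 `Nc1ccccc1/N=C\c1cc(=O)oc2cc(OCc3ccccc3)cc(OCc3ccccc3)c12` restores an aryl group: 2-aminophenyl in place of hydroxy on a double-bonded nitrogen. Within the data shown here, no step between measured compounds covers this change, so its size in this assay cannot be read from the data; the direction, if any, is expected to be toward stronger inhibition, since compound 1 and compound 2, both aryl imines, do return numbers where compound 3 does not. For compound 4 in this assay a half-maximal inhibitory concentration of about 350000 nM is estimated, within a range of 120000 nM to 1000000 nM, with a real chance that only a limit is reported.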

Compound 4, half-maximal inhibitory concentration: 624000 nM
Compound 4: the middle estimate sits 1.8-fold (0.25 log units) below what was measured, within the range that was stated.
By their numbers in this assay, from the lowest: compounds 2, 1 and 4 (each within the scatter of the next, the first and the last beyond it).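

In this assay, 2-aminophenyl in place of hydroxy on a double-bonded nitrogen leads from compound 3, reported as not active, to compound 4, which has a measured number; the size of this change cannot be read, since compound 3 has no number. Amino in place of hydroxy on an aromatic carbon gives a 1.8-fold higher number from compound 1 to compound 4 (0.25 log units; within the scatter) and so does not separate these two aryl imines, which shows that either group on that carbon is compatible with a measurable number. Nothing measured here accounts for these results.

On these data alone, whether an aryl group is needed on the double-bonded nitrogen, or a methyl or benzyl group there would also return a number, remains open. Also open, as far as these compounds go, is how a carboxylic acid or a methoxy group in place of amino on an aromatic carbon would read.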